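Adding a Phenoxy Group to Compound 2

A few compounds are considered here, and "the series" means these few. Any claim that something is new, unique, unknown or untested is made for them only; others in the source may bear on it.

Compound 1, `Cc1c(C(=O)N[C@H](C(=O)NC(CC(=O)O)C(=O)CF)C(C)C)n(C)c2ccccc12`, gives 10000 nM in a functional assay on THP-1 cells (Homo sapiens) for inhibition; a lower number here means a stronger inhibitor, a higher number a weaker inhibitor.
Compound 2, `C[C@H](NC(=O)C(=O)Nc1ccccc1)C(=O)N[C@@H](CC(=O)O)C(=O)COc1c(F)c(F)cc(F)c1F`, gives 140 nM in this assay.
Compound 3, `C[C@H](NC(=O)C(=O)Nc1ccccc1-c1ccc[nH]1)C(=O)N[C@@H](CC(=O)O)C(=O)COc1c(F)c(F)cc(F)c1F`, gives a limit, > 32000 nM, in this assay.
Compound 4, `C[C@H](NC(=O)C(=O)Nc1ccccc1Oc1ccccc1)C(=O)N[C@@H](CC(=O)O)C(=O)COc1c(F)c(F)cc(F)c1F`, has not yet been measured in this assay.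

Compound 2 holds the lowest of the two numbers in this assay; compound 1 sits a good deal higher, and compound 3 reports only a limit. Among the compounds with values here, the single measured step at the same place is an at least 220-fold higher number from compound 2 to compound 3 (2.35 log units; beyond the scatter), a change that ran up against (the limit of > 32000 nM in this assay, at which 1 of the 3 values shown sits). Compound 4 carries a related change: phenoxy in place of hydrogen on an aromatic carbon. Within the data shown here, since the one comparable step was large and upward, a large upward step is expected for a 57-fold higher number from compound 2 to compound 4 (1.76 log units; beyond the scatter) as well, though the new group is not the same one. Compound 4 is therefore estimated at 8000 nM, within 1000 nM to 32000 nM, with a real chance that only a limit is reported.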

Compound 4, half-maximal inhibitory concentration: 800 nM
Compound 4: middle estimate off by 10-fold (1.00 log units), on the high side, and the stated range ends above it.
By their numbers in this assay, from the lowest: compound 2; then compound 4; then compound 1. At a limit, above all of these: compound 3.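

Substitution on this aromatic carbon does not by itself abolish inhibition in this assay: phenoxy gives a 5.7-fold higher number from compound 2 to compound 4 (0.76 log units; beyond the scatter), a modest loss. Exchanging one group for the other gives an at least 40-fold lower number from compound 3 to compound 4 (1.60 log units; beyond the scatter), so the outcome depends on which group enters and not merely on hydrogen leaving. The value of compound 3 is only a limit, so that step has no fixed size: the limit of > 32000 nM in this assay, at which 1 of the 4 values shown sits.

As far as these compounds go, whether a methoxy group or an amine at this place would stay closer to compound 2 remains open. So does whether any group here could give a lower number than compound 2.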